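Biaryl link in place of the anilino bridge

The source may hold more compounds than are shown below. What is called first, only, known or untested is meant among the compounds shown, and "the series" means these compounds.

Compound 1 `C=C[C@@](C)(/C=C/c1ccc(Nc2ccc(OC)cc2)cc1)CCC=C(C)C` in a functional assay on HepG2 cells (Homo sapiens) for cytotoxicity, with a stated time of 72 h (a lower number here means that less compound is needed, a higher number that more compound is needed for the effect), gives > 52000 nM, which is a limit of the assay and not a number. Compound 2 `C=C[C@@](C)(/C=C/c1ccc(Nc2ccc(OC)c(OC)c2)cc1)CCC=C(C)C` gives > 52000 nM, again a limit. Compound 3 `C=C[C@@](C)(/C=C/c1ccc(Nc2ccc(C(F)(F)F)cc2)cc1)CCC=C(C)C` gives > 52000 nM, also a limit. Accordingly a step that the two limits leave unreadable from compound 1 to compound 2 and a step that the two limits leave unreadable from compound 1 to compound 3 cannot be sized; the only evidence is the limit of > 52000 nM in this assay, at which 3 of the 3 values shown sit. Compound 4 `C=C[C@@](C)(/C=C/c1ccc(-c2cccc(F)c2)cc1)CCC=C(C)C` differs from compound 1 by 3-fluorophenyl in place of (4-methoxyphenyl)amino on an aromatic carbon. Neither measured step bears on this change: both keep the arylamino bridge with its hydrogen-bond donor, which compound 4 lacks. With every value sitting at the limit, no direction is readable, and compound 4 is expected to remain near that limit, the expected step being a step that the limit leaves unreadable from compound 1 to compound 4. The estimate for compound 4 is 60000 nM, between 20000 nM and 150000 nM.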

Compound 4, half-maximal effective concentration: > 52000 nM
Compound 4: only a limit was reported; the forecaster's own chance of this, stated with the estimate: 70%; the middle value is on the limit's open side.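

Compound 4 gives > 52000 nM in this assay, which is a limit of the assay and not a number. The step from compound 1 to compound 4 cannot be read, and the series stays at one limit: the limit of > 52000 nM in this assay, at which 4 of the 4 values shown sit.

The compounds shown leave open which change to the shared core, if any, would give a measurable value in this assay.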